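A few compounds are considered here, and "the series" means these few. Any claim that something is new, unique, unknown or untested is made for them only; others in the source may bear on it.

Compound 1 `CCNc1ncc(C(=O)O)c2nc(-c3ccco3)nn12` gives > 10000 nM in a functional assay on CHO cells for antagonist activity at adenosine receptor A2b (Homo sapiens) (a higher number here means a weaker inhibitor, a lower number a stronger inhibitor), which is a limit of the assay and not a number.
Compound 2 `CCCCC(CC)CNc1ncc(C(=O)O)c2nc(-c3ccco3)nn12` likewise gives the limit > 10000 nM.
Compound 3 `COc1ccc(CNc2ncc(C(=O)O)c3nc(-c4ccco4)nn23)cc1` gives the limit > 30000 nM.

Compound 3 therefore stands at a limit, as do the two others, and none of the three yields a number. The steps a step that the two limits leave unreadable from compound 1 to compound 2, a step that the two limits leave unreadable from compound 1 to compound 3 and a step that the two limits leave unreadable from compound 2 to compound 3 all remain unreadable, since every value sits at one of the limits the limit of > 10000 nM in this assay, at which 2 of the 3 values shown sit, or (the limit of > 30000 nM in this assay, at which 1 of the 3 values shown sits). Compound 4 `O=C(O)c1cnc(NCc2ccc(F)cc2)n2nc(-c3ccco3)nc12` differs from compound 3 by fluoro in place of methoxy on an aromatic carbon. For the measured compounds named here, no measured step offers a readable size, so no direction can be drawn from them. Compound 4 is thus expected to remain near the limits, with the expected step of an at least 1.5-fold lower number from compound 3 to compound 4 (0.17 log units; that floor lies within the scatter) carrying little weight. The estimate for compound 4 in this assay is 20000 nM, within 5000 nM to 100000 nM.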

Compound 4, inhibition constant: > 30000 nM
Compound 4 was reported as a limit; the forecaster's own chance of this, stated with the estimate: 75%; middle value at least 1.5-fold (0.17 log units) away from the limit.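

For the compounds shown here, compound 4 gives only a limit of the assay, as do compound 1, compound 2 and compound 3, so no step to compound 4 can be read. The compounds shown leave open how strongly any of them acts in this assay, and whether fluoro in place of methoxy changes anything there.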